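A few compounds are considered here, and "the series" means these few. Any claim that something is new, unique, unknown or untested is made for them only; others in the source may bear on it.

Three compounds share one core. Compound 1 `Cc1ccc(S(=O)(=O)/C(=C/c2ccc(C)s2)C(=O)c2ccc(Br)cc2)cc1`, compound 2 `O=C(/C(=C\c1ccc(Br)c(O)c1)S(=O)(=O)c1ccc(Br)cc1)c1ccc(Br)cc1` and compound 3 `COc1ccccc1/C=C(\C(=O)c1ccc(Cl)cc1)S(=O)(=O)Cc1ccc(Cl)cc1` were tested in a functional assay on DU-145 cells (Homo sapiens) for inhibition, read by trypan blue exclusion, with a stated time of 96 h; on this read-out lower numbers stand for stronger inhibition of growth and higher numbers for weaker inhibition of growth. In this assay compound 1 gives 25000 nM, compound 2 gives 50000 nM and compound 3 gives 25000 nM. Compound 2 carries the highest of the three numbers, yet each of the other two lies within the usual scatter of it, so the three cannot be ranked. Compound 4 `COc1cccc(OC)c1/C=C(\C(=O)c1ccc(Br)cc1)S(=O)(=O)c1ccc(Br)cc1` is not yet measured; it differs from compound 2 by 2,6-dimethoxyphenyl in place of 4-bromo-3-hydroxyphenyl on a double-bonded chain carbon bound to a double-bonded chain carbon. Among the compounds with values here, no pair of measured compounds differs in just one place, so no measured step guides this change. Because compound 2 gives 50000 nM and the other two numbers sit close to it, compound 4 is expected to stay near that level, the estimated step being a 1.7-fold lower number from compound 2 to compound 4 (0.22 log units; within the scatter), not beyond the scatter. Compound 4 is estimated at 30000 nM, within 10000 nM to 100000 nM.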

Compound 4, concentration for 50% growth inhibition: 10000 nM
Beside the measured number, compound 4's estimate is 3.0-fold (0.48 log units) above it; the measured number falls inside the stated range.
By their numbers in this assay, from the lowest: compound 4; then compounds 1, 3 and 2 (each within the scatter of the next).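

In this assay, within the data shown here, the swap of 4-bromo-3-hydroxyphenyl for 2,6-dimethoxyphenyl gives a 5.0-fold lower number from compound 2 to compound 4 (0.70 log units; beyond the scatter) and is the only step here between compounds differing in one place, showing that this group on a double-bonded chain carbon can shift growth inhibition beyond the scatter. The whole group changes at once, so the loss of bromine, the loss of hydroxy and the gain of methoxy groups cannot be told apart. No supporting evidence explains the step. As far as these compounds go, what an amine or a carboxylic acid on this ring would do stays open, as does whether a single methoxy group would give the same shift.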